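A few compounds are considered here, and "the series" means these few. Any claim that something is new, unique, unknown or untested is made for them only; others in the source may bear on it.

Working notes on the series, read in a functional assay on renal cells (Homo sapiens) for antiproliferative activity; a lower number here means a stronger inhibitor of growth, a higher number a weaker inhibitor of growth. Of the compounds shown here, three have values so far. Compound 2 (`N=C(N)N/N=C/c1c(-c2ccccn2)nc2sc(Cl)cn12`) gives 7940 nM, the lowest number of the three. Compound 3 (`N=C(N)N/N=C/c1c(-c2cccnc2)nc2sc(Cl)cn12`) gives 18200 nM, and compound 1 (`Cc1cn2c(/C=N/NC(=N)N)c(-c3ccncc3)nc2s1`) gives 23400 nM, so these two stand level within the scatter and both sit above compound 2.

The next step leads to compound 4 (`N=C(N)N/N=C/c1c(-c2ccncc2)nc2sc(Cl)cn12`), with pyridin-4-yl in place of pyridin-3-yl on an aromatic carbon of a five-membered aromatic ring with 2 nitrogen: pyridin-4-yl in place of pyridin-3-yl on an aromatic carbon.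

Going by the values given here, only one measured step bears directly on this exchange: a 2.3-fold higher number from compound 2 to compound 3 (0.36 log units; beyond the scatter). It is a modest step, and it concerns a different pair of pyridinyl groups, so it gives neither a firm size nor a firm direction here. Compound 1 offers indirect support, since it also carries pyridin-4-yl, on a core that differs elsewhere, and its value of 23400 nM falls in the same region as compound 3. No step larger than the modest one is therefore expected in this assay, and no direction is favoured.

The expected change is a 1.1-fold lower number from compound 3 to compound 4 (0.03 log units; within the scatter), which would not be a clear step beyond the scatter. For compound 4 the estimated value is 17000 nM, with an expected range of 8500 nM to 33000 nM.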

Compound 4, concentration for 50% growth inhibition: 6610 nM
The estimate for compound 4 lay 2.6-fold (0.41 log units) above the measured number; measured number outside the range, below it.
By their numbers in this assay, from the lowest: compounds 4 and 2 (each within the scatter of the next); then compounds 3 and 1 (each within the scatter of the next).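

In this assay, pyridin-4-yl in place of pyridin-3-yl on this aromatic carbon is a real change (that is, a 2.8-fold lower number from compound 3 to compound 4 (0.44 log units; beyond the scatter)), so the exchange of one pyridinyl isomer for another at this position is not neutral in this pair. Pyridin-4-yl and pyridin-2-yl stand level (with a 1.2-fold lower number from compound 2 to compound 4 (0.08 log units; within the scatter)), which leaves pyridin-3-yl as the one isomer of the three apart from the other two, with the higher number, and so the three do not run in the order of their names. Going by these compounds alone, compound 4 also gives the first single-place reading of the other substituent, chloro in place of methyl on an aromatic carbon (with a 3.5-fold lower number from compound 1 to compound 4 (0.55 log units; beyond the scatter)), a modest step that the earlier comparison of compound 1 with compound 3 could not isolate. Nothing measured here accounts for either step.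

As far as these compounds go, whether the chloro over methyl step carries over when pyridin-2-yl or pyridin-3-yl is the ring present remains open. Also open, from the compounds shown here alone, is how a plain phenyl ring, or an aminopyridine with an added amine on the pyridine, would read on this aromatic carbon.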